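The source may hold more compounds than are shown below. What is called first, only, known or untested is meant among the compounds shown, and "the series" means these compounds.

Compound 1 `COc1cc2c(Nc3cccc([N+](=O)[O-])c3)ncnc2c(OC)c1OC` gives 24400 nM in a functional assay on PC-3 cells (Homo sapiens) for inhibition, read by MTT assay, with a stated time of 72 h; on this read-out lower numbers stand for stronger inhibition and higher numbers for weaker inhibition.
Compound 2 `COc1cc2c(N[C@@H](C)c3ccccc3)ncnc2c(OC)c1OC` gives 10000 nM.
Compound 3 `COc1cc2c(Nc3ccc(O)cc3)ncnc2c(OC)c1OC` gives 20100 nM.

All three share the same core and differ only in the group carried on the nitrogen attached to that core. Within the data shown here, of the three numbers, that of compound 3 is the second highest, though its gaps to both other compounds fall within the usual scatter: compound 1 is nearest, and the only single-point step measured so far, a 2.0-fold higher number from compound 2 to compound 3 (0.30 log units; within the scatter), also stays within the scatter.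

Compound 4 `COc1cc2c(Nc3cccc(Cl)c3)ncnc2c(OC)c1OC` has not yet been measured. Its change from compound 3 is 3-chlorophenyl in place of 4-hydroxyphenyl on a nitrogen on an aromatic ring. Among the measured compounds shown here, no measured step exchanges one substituent on this phenyl for another, so nothing bears on it directly. What is known is that compound 1, which carries a nitro group on its phenyl, and compound 3, which carries a hydroxy group, give numbers within the scatter of each other, and that the larger swap from compound 2 to compound 3 likewise moved little. The expectation is therefore a step of a 1.1-fold lower number from compound 3 to compound 4 (0.05 log units; within the scatter), not beyond the scatter. Compound 4 is estimated at 18000 nM, with a range from 6000 nM to 50000 nM.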

Compound 4, half-maximal inhibitory concentration: 19000 nM
Beside the measured number, compound 4's estimate is 1.1-fold (0.02 log units) below it; the range from low to high includes it.
By their numbers in this assay, from the lowest: compounds 2, 4, 3 and 1 (each within the scatter of the next, the first and the last beyond it).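

In this assay, among these compounds, 3-chlorophenyl in place of 4-hydroxyphenyl gives a 1.1-fold lower number from compound 3 to compound 4 (0.02 log units; within the scatter) even though the hydrogen-bond donor and acceptor counted on the leaving group have no counterpart on the entering one, so at this position on the nitrogen that difference in counts comes with no step beyond the scatter. Among the compounds shown here, compound 4 also provides the first direct exchange of one phenyl substituent for another: chloro in place of nitro on an aromatic carbon gives a 1.3-fold lower number from compound 1 to compound 4 (0.11 log units; within the scatter) and stays within the scatter, as does 3-chlorophenyl in place of 1-phenylethyl, which gives a 1.9-fold higher number from compound 2 to compound 4 (0.28 log units; within the scatter) and so adds a second comparison between an aryl group and the branched group on this nitrogen. Nothing measured here accounts for how closely these different groups read in this assay.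

The compounds shown leave open whether an amine or a carboxylic acid on the phenyl would give a step beyond the scatter. They also leave open whether a longer chain on the nitrogen would do so.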